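The compounds below may be only part of what the source reports. "The series", "measured", "known", "first", "only" and "open" are said of these compounds alone.

Measured compounds:
Compound 1, `O=C(NNc1nc2ccccc2nc1Cc1ccccc1)c1ccccc1` — in an assay for inhibition of Amine oxidase [flavin-containing] A (Bos taurus), read by fluorescence, with a stated time of 60 min (a higher number here means a weaker inhibitor, a lower number a stronger inhibitor), compound 1 gives 78 nM.
Compound 2, `O=C(NNc1nc2ccccc2nc1Cc1ccccc1)c1ccc(Cl)cc1` — compound 2 gives 34 nM.
Compound 3, `O=C(Cn1c(=O)c(Cc2ccccc2)nc2ccccc21)N/N=C/c1ccccc1` — compound 3 gives 3.1 nM.

Compound 3 has the lowest number of the three, and its gaps to compound 2 and compound 1 are both beyond the scatter, so it is the strongest inhibitor here. Compound 4, `C/C(=N\NC(=O)Cn1c(=O)c(Cc2ccccc2)nc2ccccc21)c1ccc(O)cc1`, differs from compound 3 by a group of 10 heavy atoms (8 carbon, 1 nitrogen, 1 oxygen; one six-membered aromatic ring of carbon only) in place of a group of 8 heavy atoms (7 carbon, 1 nitrogen; one six-membered aromatic ring of carbon only), on an amide-type nitrogen. For the measured compounds named here, the only measured step, a 2.3-fold lower number from compound 1 to compound 2 (0.36 log units; beyond the scatter), concerns a different part of the molecule and a different core, so it gives little guidance; no step on this amide-type nitrogen has been measured. Compound 4 is therefore expected to stay close to compound 3, with a step of about a 1.6-fold higher number from compound 3 to compound 4 (0.21 log units; within the scatter). The estimate for compound 4 is 5 nM, within 1.5 nM to 20 nM.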

Compound 4, half-maximal inhibitory concentration: 1.6 nM
Compound 4: the middle estimate sits 3.1-fold (0.49 log units) above what was measured; the measured number falls inside the stated range.
By their numbers in this assay, from the lowest: compounds 4 and 3 (each within the scatter of the next); then compound 2; then compound 1.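

In this assay the first step measured on this amide-type nitrogen is a 1.9-fold lower number from compound 3 to compound 4 (0.29 log units; within the scatter) and so the group of 10 heavy atoms, which carries a hydrogen-bond donor, is tolerated in place of the group of 8 heavy atoms. No other information bears on this result.

The compounds shown leave open whether a group with no aromatic ring, such as a longer chain or a carboxylic acid, would be tolerated on this nitrogen. They also leave open whether chloro in place of hydrogen on an aromatic carbon would change the number on the core of compound 3.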